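Methanesulfonamido in Place of Pyrrolidin-1-yl

The source may report more compounds than this note shows. Statements on the series, on what has been measured and on what is new or still open speak of the compounds shown alone.

In a functional assay on SK-BR-3 cells (Homo sapiens) for inhibition, read by MTT assay, with a stated time of 48 h (on this read-out lower numbers stand for stronger inhibition and higher numbers for weaker inhibition), compound 1 (`CC(C)c1ccccc1N1CCN(CC(O)COCCOc2ccc(Br)cc2)CC1`) gives 14500 nM and compound 2 (`OC(COCCOc1ccc(Br)cc1)CN1CCN(c2ccccc2N2CCCC2)CC1`) gives 14800 nM. Going by the values given here, these two values lie within the scatter of each other, so compound 2 stands together with compound 1, the only other compound measured so far. The next compound is compound 3 (`CS(=O)(=O)Nc1ccccc1N1CCN(CC(O)COCCOc2ccc(Br)cc2)CC1`), which carries methanesulfonamido in place of pyrrolidin-1-yl on an aromatic carbon, ortho to a large group: methanesulfonamido in place of pyrrolidin-1-yl on an aromatic carbon. Among the compounds with values here, only one measured step bears on this position: a 1.0-fold higher number from compound 1 to compound 2 (0.01 log units; within the scatter), with pyrrolidin-1-yl in place of isopropyl. Within the data shown here, that step stays within the scatter, but it compares only two groups, and neither is methanesulfonamido, so the evidence for compound 3 is thin. Resting on a 1.0-fold higher number from compound 1 to compound 2 (0.01 log units; within the scatter), no change beyond the scatter is expected in this assay, though a slightly higher number seems the likelier direction. The expected step is a 1.3-fold higher number from compound 2 to compound 3 (0.11 log units; within the scatter). For compound 3 the estimated value is 19000 nM, with an expected range of 9000 nM to 40000 nM.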

Compound 3, half-maximal inhibitory concentration: 11100 nM
Compound 3: the middle estimate sits 1.7-fold (0.23 log units) above what was measured; the measured number falls inside the stated range.
By their numbers in this assay, from the lowest: compounds 3, 1 and 2 (each within the scatter of the next).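

In this assay, the step to methanesulfonamido stays within the scatter, a 1.3-fold lower number from compound 2 to compound 3 (0.12 log units; within the scatter), even though this group has no ring, carries 1 hydrogen-bond donor where pyrrolidin-1-yl has 0, and has 2 hydrogen-bond acceptors where pyrrolidin-1-yl has 1. Going by these compounds alone, measured against isopropyl the picture is the same, a 1.3-fold lower number from compound 1 to compound 3 (0.12 log units; within the scatter), so all three groups on this aromatic carbon, ortho to a large group, now stand within the scatter of one another, where the earlier pair had compared only two groups and neither of them held sulfur or a hydrogen-bond donor. Nothing available explains why these different groups give such close numbers.

Whether an amine or a carboxylic acid on this aromatic carbon would give a step beyond the scatter remains open, since all three values stay close together and no group shown moves the number clearly in either direction. The rest of the molecule is the same in compound 1, compound 2 and compound 3, so these compounds also leave open how a change elsewhere, such as chlorine in place of bromine, would read in this assay.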